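The source may report more compounds than this note shows. Statements on the series, on what has been measured and on what is new or still open speak of the compounds shown alone.

Measured compounds:
- compound 1, `COc1ccc(C(=O)Oc2cc3c(cc2C)[C@@H](C(C)C)CC=C3C)cc1`: 60.6%
- compound 2, `Cc1cc2c(C(C)C)ccc(C)c2cc1OC(=O)c1cccc(C(F)(F)F)c1`: 26.7%
- compound 3, `CC1=CC[C@H](C(C)C)c2cc(C)c(OC(=O)c3cccc(Cl)c3)cc21`: 23.4%

In a functional assay on PC-3 cells (Homo sapiens) for antiproliferative activity, read by sulforhodamine B assay, with a stated time of 48 h, tested at 50 uM (a higher number here means more inhibition at the concentration tested (going by the name of the read-out), a lower number less inhibition), compound 2 gives 26.7%, the second highest of the three numbers. Its nearest neighbour is compound 3 with 23.4%, a gap that stays within the scatter, so the two are not told apart. Compound 1, with 60.6%, lies beyond the scatter above compound 2.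

Compound 4, `COc1cccc(C(=O)Oc2cc3c(C)ccc(C(C)C)c3cc2C)c1`, differs from compound 2 in one place: methoxy in place of trifluoromethyl on an aromatic carbon. For the measured compounds named here, the one measured step that bears on this is a number 37.2 percentage points lower from compound 1 to compound 3 (beyond the scatter), where a halogenated phenyl replaced a 4-methoxyphenyl on the carbonyl carbon. Going by the values given here, the step from compound 2 to compound 4 runs the other way, bringing a methoxy in, though here it sits meta to a large group rather than in the 4-methoxyphenyl arrangement of compound 1, and there is no measured pair that isolates that placement. On this basis, a rise in this assay is expected, but a smaller one than the drop from compound 1 to compound 3, and with wide uncertainty. Compound 4 is therefore estimated at 40%, with a range from 22% to 60%, meaning an expected step of a number 13.3 percentage points higher from compound 2 to compound 4 (beyond the scatter).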

Compound 4, a percentage reported as inhibition, at one concentration (the size of the read-out at that concentration, not a potency): 12.5%
Estimate against measurement, compound 4: 27.5 percentage points above, outside the stated range (below it).
By their numbers in this assay, from the lowest: compound 4; then compounds 3 and 2 (each within the scatter of the next); then compound 1.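

In this assay, putting methoxy in place of trifluoromethyl on an aromatic carbon, meta to a large group, gives a fall: a number 14.2 percentage points lower from compound 2 to compound 4 (beyond the scatter). The earlier step concerned a 4-methoxyphenyl group and said nothing about this position, and this result shows that methoxy here does not raise the number, so the presence of a methoxy group alone does not go with higher inhibition across the compounds shown. Nothing available here explains this fall.

Compound 4 and compound 1 differ in more than one place, so the compounds shown do not separate the placement of the methoxy from the other differences in the core. Going by these compounds, how an amine, a carboxylic acid or a hydroxyl group on this same aromatic carbon would read in this assay also remains open.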